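The source may hold more compounds than are shown below. What is called first, only, known or untested is meant among the compounds shown, and "the series" means these compounds.

Measured so far:
compound 1 `COc1ccc(C2=C(c3cc(OC)c(OC)c(OC)c3)C(=O)C(OC(C)=O)C2)cc1Cl` — in an ADME assay on HT-29 cells (Homo sapiens) for cytotoxicity, read by MTT assay, with a stated time of 72 h (a higher number here means a weaker inhibitor, a lower number a stronger inhibitor), compound 1 gives < 1 ug/mL
compound 2 `COc1ccc(C2=C(c3cc(OC)c(OC)c(OC)c3)C(=O)C(O)C2)cc1` — in this assay compound 2 gives < 1 ug/mL

Compound 2 stands at a limit of the assay, not at a number: in this assay compound 2 reads < 1 ug/mL. The same holds for compound 1 in its own right, its reading in this assay being < 1 ug/mL, again a limit. Within the data shown here, both values shown therefore sit at the limit of < 1 ug/mL in this assay, at which 2 of the 2 values shown sit, so the series so far gives no numerical spread, only a ceiling under which both compounds lie. Among the measured compounds shown here, compound 1 and compound 2 differ in more than one place and no step between them is given; their two values show only that each is a limit.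

Compound 3 `COc1ccc(C2=C(c3cc(OC)c(OC)c(OC)c3)C(=O)C(O)C2)cc1Cl` is the unmeasured member. It differs from compound 2 by chloro in place of hydrogen on an aromatic carbon. Compound 1 already carries this chloro on the same ring and sits at the limit as well. In this assay no step beyond the scatter is expected from compound 2 to compound 3; the estimated step is a step that the limit leaves unreadable from compound 2 to compound 3. Compound 3 is expected at 0.5 ug/mL, within 0.1 ug/mL to 1.5 ug/mL, most likely reported once more as a limit.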

Compound 3, half-maximal inhibitory concentration: < 1 ug/mL
Compound 3: no number, only a limit; the forecaster's own chance of this, stated with the estimate: 80%; the middle value does not contradict the limit.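

No new step can be read from compound 2 to compound 3 or from compound 1 to compound 3 in this assay, since every reading there is a limit: the limit of < 1 ug/mL in this assay, at which 3 of the 3 values shown sit.

The compounds shown leave open what actual values lie behind these limits, and so whether chloro in place of hydrogen on the aromatic carbon, or hydrogen in place of acetyl on the oxygen, alters the reading at all.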